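A few compounds are considered here, and "the series" means these few. Any claim that something is new, unique, unknown or untested is made for them only; others in the source may bear on it.

Within the data shown here, in a functional assay on MDA-MB-231 cells (Homo sapiens) for inhibition, read by MTT assay, with a stated time of 72 h (a lower number here means a stronger inhibitor, a higher number a weaker inhibitor), two compounds have numbers so far. Compound 1 `O=C(CSc1nc(Nc2ccccc2)c2ccccc2n1)Nc1cccc(Br)c1` gives 17500 nM. Compound 2 `O=C(CSc1nc(Nc2ccccc2)c2ccccc2n1)Nc1cccc([N+](=O)[O-])c1` gives 33000 nM. Among the measured compounds shown here, the only step between them, a 1.9-fold higher number from compound 1 to compound 2 (0.28 log units; within the scatter), falls within the scatter, so compound 2 stands together with compound 1 and neither is set apart from the other. Compound 3 `O=C(CSc1nc(Nc2ccccc2)c2ccccc2n1)Nc1ccc([N+](=O)[O-])cc1` remains to be measured; it differs from compound 2 by 4-nitrophenyl in place of 3-nitrophenyl on an amide-type nitrogen. For the measured compounds named here, no measured step bears on this change: the single known step exchanges a bromo for a nitro group and does not shift a group from one carbon of the ring to another. With nothing pointing in either direction, no step beyond the scatter is expected in this assay, and compound 3 is expected to give 30000 nM, within a range from 10000 nM to 90000 nM. The expected step of a 1.1-fold lower number from compound 2 to compound 3 (0.04 log units; within the scatter) therefore rests on the number of compound 2 alone.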

Compound 3, half-maximal inhibitory concentration: 16800 nM
The estimate for compound 3 lay 1.8-fold (0.25 log units) above the measured number, and the stated range covers the measured number.
By their numbers in this assay, from the lowest: compounds 3, 1 and 2 (each within the scatter of the next).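

Shifting the nitro group from 3-nitrophenyl to 4-nitrophenyl on the amide-type nitrogen is the first change of ring place seen at this position, and in this assay it gives a 2.0-fold lower number from compound 2 to compound 3 (0.29 log units; within the scatter). Among these compounds, replacing 3-bromophenyl with 4-nitrophenyl gives a 1.0-fold lower number from compound 1 to compound 3 (0.02 log units; within the scatter), so the three compounds now vary both the group and its place on the ring, and no step among them lies beyond the scatter. No available evidence bears on this result.

From the compounds shown here alone, whether an amine or a carboxylic acid in place of the nitro group, or a longer chain in place of the phenyl ring, would move the number beyond the scatter remains open. So does the effect of any change elsewhere in the shared core.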